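From tert-Butoxy to Ethylamino on the Carbonyl Carbon

The source may hold more compounds than are shown below. What is called first, only, known or untested is meant among the compounds shown, and "the series" means these compounds.

Measured so far:
Compound 1 `CC1=C(C(=O)OC(C)(C)C)C(c2ccoc2)NC(=O)N1`: 2%
Compound 2 `CC1=C(C(=O)OC(C)(C)C)C(c2ccoc2)NC(=O)N1C`: 12%

In an assay on membranes from HeLa cells for displacement of a labelled ligand from adenosine receptor A3 (Homo sapiens), read by scintillation counting, with a stated time of 180 min, tested at 1 uM (a lower number here means less inhibition, a higher number more inhibition at the concentration tested (going by the name of the read-out)), compound 1 gives 2%, the lowest of the two numbers measured. Its nearest neighbour is compound 2 with 12%, and the step of a number 10 percentage points higher from compound 1 to compound 2 (within the scatter) lies within the scatter, so the two compounds cannot be told apart on this read-out.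

Compound 3 `CCNC(=O)C1=C(C)NC(=O)NC1c1ccoc1` is the compound still to be measured. It differs from compound 1 in one place: ethylamino in place of tert-butoxy on a carbonyl carbon. Among the measured compounds shown here, the only measured step, a number 10 percentage points higher from compound 1 to compound 2 (within the scatter), concerns methyl in place of hydrogen on an amide-type nitrogen in a ring, not the carbonyl carbon, so no measured step bears on this change. With nothing to point either way, no step beyond the scatter is expected in this assay. Compound 3 is therefore estimated at 5%, within -5% to 20%. The expected step of a number 3 percentage points higher from compound 1 to compound 3 (within the scatter) is essentially no change.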

Compound 3, a percentage reported as inhibition, at one concentration (the size of the read-out at that concentration, not a potency): 1%
Compound 3: the middle estimate sits 4 percentage points above what was measured, and the stated range covers the measured number.
By their numbers in this assay, from the lowest: compounds 3, 1 and 2 (each within the scatter of the next, the first and the last beyond it).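

On the carbonyl carbon, ethylamino in place of tert-butoxy gives, in this assay, a number 1 percentage points lower from compound 1 to compound 3 (within the scatter) and so leaves no readable mark at the one concentration tested. Among the compounds shown here, this is the first measured change at this place, and it shows that the read-out does not separate these two groups, even though ethylamino brings a hydrogen-bond donor and fewer heavy atoms than tert-butoxy. No measurement on hand explains this result.

Still open, on these data alone, is whether a carboxylic acid or a longer chain such as hexylamino on this carbonyl carbon would give a clearly different number in this assay. As far as these compounds go, it is also open whether ethylamino would behave the same way on a core carrying the methyl on the ring's amide-type nitrogen.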